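Aryl alkyne acid series: thiophene to phenyl step

The source may report more compounds than this note shows. Statements on the series, on what has been measured and on what is new or still open speak of the compounds shown alone.

Two compounds of the series carry a measurement in an assay on CHO cells for displacement of a labelled ligand from prostaglandin D2 receptor 2 (Homo sapiens), read by scintillation counting; on this read-out lower numbers stand for stronger inhibition and higher numbers for weaker inhibition. Compound 1 `CS(=O)(=O)c1ccc(C#Cc2cc(Cl)ccc2OCC(=O)O)cc1` gives 86 nM in this assay. Compound 2 `O=C(O)COc1ccc(Cl)cc1C#Cc1ccc(Cl)s1` gives 183 nM in this assay, which is the higher of the two numbers; the gap to compound 1 lies beyond the usual scatter, so compound 2 binds less tightly than compound 1. Going by the values given here, no pair of measured compounds differs in only one place, so no single-point step has been observed directly.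

Compound 3 `O=C(O)COc1ccc(Cl)cc1C#Cc1ccccc1` is not yet measured. It differs from compound 2 by phenyl in place of 5-chlorothiophen-2-yl on a triple-bonded carbon. No comparable change has been followed in this assay, so the expectation rests only on the two values at hand. Removing the chlorinated five-membered ring in favour of a bare six-membered carbon ring is expected to cost some affinity, with the step from compound 2 to compound 3 estimated at a 1.9-fold higher number from compound 2 to compound 3 (0.28 log units; within the scatter), most likely beyond the scatter but not large. Compound 3 is therefore expected to give 350 nM in this assay, within a range of 100 nM to 1200 nM.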

Compound 3, inhibition constant: 108 nM
The estimate for compound 3 lay 3.2-fold (0.51 log units) above the measured number; measured number inside the range.
By their numbers in this assay, from the lowest: compounds 1, 3 and 2 (each within the scatter of the next, the first and the last beyond it).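

In this assay, phenyl in place of 5-chlorothiophen-2-yl on a triple-bonded carbon gives a 1.7-fold lower number from compound 2 to compound 3 (0.23 log units; within the scatter), so this pair does not separate the two rings, and neither the chlorine nor the sulfur is shown to be needed for binding at this position. Hydrogen in place of methylsulfonyl on an aromatic carbon gives a 1.3-fold higher number from compound 1 to compound 3 (0.10 log units; within the scatter), so the unsubstituted phenyl and the methylsulfonyl-bearing ring also cannot be told apart, and these are the first single-place comparisons in the series, both within the scatter. No supporting measurement is available to explain either step.

The separate contributions of the chlorine and the ring swap remain unresolved, since thiophen-2-yl without chlorine does not appear among the compounds shown. On these data alone, it also remains open whether any group on the triple-bonded carbon can move the number beyond the scatter, for example cyclohexyl in place of the aromatic ring, or an aminomethyl or carboxylic acid group carried on the phenyl ring.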